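Adding a second ring-bearing group to compound 2

The source may report more compounds than this note shows. Statements on the series, on what has been measured and on what is new or still open speak of the compounds shown alone.

Measured in an ADME assay on A549 cells (Homo sapiens) for cytotoxicity, read by resazurin assay, with a stated time of 48 h; a higher number here means that more compound is tolerated, a lower number that less compound is tolerated:
- compound 1 `CCCNc1ccc(NC(=O)c2cc(Cl)ccc2O)c(Cl)c1`: 22500 nM
- compound 2 `CC1(Nc2ccc(NC(=O)c3cc(Cl)ccc3O)c(Cl)c2)CCCC1`: 157000 nM

Of these two compounds, compound 2 has the higher number at 157000 nM, so cells tolerate more of it. Compound 3 `CC1(ON(c2ccc(NC(=O)c3cc(Cl)ccc3O)c(Cl)c2)C2(C)CCCC2)CCCC1` is not yet measured. It carries (1-methylcyclopentyl)oxy in place of hydrogen on a nitrogen on an aromatic ring.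

Going by the values given here, only one measured step bears on this change, and it involves the same nitrogen. With 1-methylcyclopentyl in place of propyl, that step is a 7.0-fold higher number from compound 1 to compound 2 (0.84 log units; beyond the scatter). It is a modest guide, since it replaces one group with another and does not replace a hydrogen. It therefore gives no firm direction, and no step beyond the usual scatter is expected in this assay. The expected change is a 1.2-fold lower number from compound 2 to compound 3 (0.08 log units; within the scatter). The estimate for compound 3 is 130000 nM, with an expected range from 35000 nM to 350000 nM.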

Compound 3, half-maximal cytotoxic concentration: 18000 nM
Compound 3: the middle estimate sits 7.2-fold (0.86 log units) above what was measured; measured number outside the range, below it.
By their numbers in this assay, from the lowest: compounds 3 and 1 (each within the scatter of the next); then compound 2.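

Replacing the hydrogen on this nitrogen with (1-methylcyclopentyl)oxy gives an 8.7-fold lower number from compound 2 to compound 3 (0.94 log units; beyond the scatter) in this assay, so cells tolerate less of the compound with the added group. The earlier step at this nitrogen swapped one group for another, whereas this one shows that the remaining hydrogen can also be replaced with a change beyond the usual scatter. The two steps run in opposite directions, with a 7.0-fold higher number from compound 1 to compound 2 (0.84 log units; beyond the scatter) before it, so adding a 1-methylcyclopentyl-containing group to this nitrogen does not move the number in one fixed direction across these compounds.

On these data alone, it remains open whether the oxygen link or the carbon ring accounts for the lower number, and a methoxy or hydroxyl group on the same nitrogen would help separate the two. Nothing measured here explains the change.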